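A few compounds are considered here, and "the series" means these few. Any claim that something is new, unique, unknown or untested is made for them only; others in the source may bear on it.

Measured compounds:
Compound 1 `CCCn1c(=O)[nH]c2nc(-c3ccc(S(=O)(=O)N4CCN(c5ccccc5Cl)CC4)cc3)[nH]c2c1=O` — in an assay on CHO cells for displacement of a labelled ligand from adenosine receptor A3 (Homo sapiens), read by scintillation counting, with a stated time of 45 min, in the presence of a further agent that is not named here (a lower number here means a stronger inhibitor, a higher number a weaker inhibitor), compound 1 gives > 1000 nM, which is a limit of the assay and not a number.
Compound 2 `CCCn1c(=O)[nH]c2nc(-c3ccc(S(=O)(=O)N4CCN(c5ccccc5C)CC4)cc3)[nH]c2c1=O` — in this assay compound 2 gives > 1000 nM, again a limit of the assay.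
Compound 3 `CCCn1c(=O)[nH]c2nc(-c3ccc(S(=O)(=O)N4CCN(Cc5cccc(C)c5)CC4)cc3)[nH]c2c1=O` — in this assay compound 3 gives > 1000 nM, also a limit of the assay.

Compound 3 thus stands at the same limit as the other two, since (the limit of > 1000 nM in this assay, at which 3 of the 3 values shown sit). For the measured compounds named here, none of the measured steps can be read: a step that the two limits leave unreadable from compound 1 to compound 2, a step that the two limits leave unreadable from compound 1 to compound 3 and a step that the two limits leave unreadable from compound 2 to compound 3 all lie between limits, so the change from a 2-chlorophenyl or 2-methylphenyl group to the 3-methylbenzyl group on the ring nitrogen gave no readable movement.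

The account now turns to compound 4 `CCCn1c(=O)[nH]c2nc(-c3ccc(S(=O)(=O)N4CCN(c5ccc(C)cc5)CC4)cc3)[nH]c2c1=O`, which differs from compound 3 as follows: 4-methylphenyl in place of 3-methylbenzyl on an amine nitrogen in a ring. Going by the values given here, no measured step bears directly on this change, and the three values shown give no direction. In this assay compound 4 is therefore expected most likely to sit at the limit as well, with an estimate of 3000 nM, ranging from 1000 nM to 15000 nM. The expected step is a step that the limit leaves unreadable from compound 3 to compound 4, which cannot be set apart from the scatter.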

Compound 4, inhibition constant: > 1000 nM
Compound 4 ended at the assay's limit; the forecaster's own chance of this, stated with the estimate: 80%; the middle value is on the limit's open side.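

In this assay compound 4 gives > 1000 nM, which is a limit of the assay and not a number. Its steps from compound 1, compound 2 and compound 3 therefore cannot be read: the limit of > 1000 nM in this assay, at which 4 of the 4 values shown sit. The compounds shown leave open how strong an inhibitor any of them is, and whether changing the group on the ring nitrogen moves the value at all.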